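The source may hold more compounds than are shown below. What is called first, only, known or untested is meant among the compounds shown, and "the series" means these compounds.

Working notes on the series. In a functional assay on U2OS cells (Homo sapiens) for inhibition, read by colorimetric assay, with a stated time of 3 days (a lower number here means a stronger inhibitor, a higher number a weaker inhibitor), compound 1 `COc1ccc(-c2cnc(NC(=O)CCCCCCNC(=O)C(O)(O)C(F)(F)F)s2)cc1` gives 1310 nM and compound 2 `O=C(CCCCCCNC(=O)C(O)(O)C(F)(F)F)Nc1ncc(-c2ccc(Br)cc2)s1` gives 1090 nM. Going by the values given here, these are the only two measured values so far, and compound 2 stands level with compound 1 within the scatter.

The next member is compound 3 `O=C(CCCCCCNC(=O)C(O)(O)C(F)(F)F)Nc1ncc(-c2ccc(O)cc2)s1`, with hydroxy in place of bromo on an aromatic carbon. Among the compounds with values here, one measured step bears on this change, as it falls at the same place on the ring. That step, a 1.2-fold lower number from compound 1 to compound 2 (0.08 log units; within the scatter), swapped methoxy for bromo and stayed within the scatter. Within the data shown here, no hydroxy compound has been measured yet, so this is indirect evidence. No step beyond the scatter is therefore expected in this assay, and neither direction is favoured.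

Compound 3 is expected at 1300 nM, with an estimated range of 550 nM to 3000 nM. The expected step is a 1.2-fold higher number from compound 2 to compound 3 (0.08 log units; within the scatter).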

Compound 3, half-maximal inhibitory concentration: 740 nM
Estimate against measurement, compound 3: 1.8-fold (0.24 log units) above, and the stated range covers the measured number.
By their numbers in this assay, from the lowest: compounds 3, 2 and 1 (each within the scatter of the next).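

In this assay the change from 4-bromophenyl to 4-hydroxyphenyl gives a step that stays within the scatter (a 1.5-fold lower number from compound 2 to compound 3 (0.17 log units; within the scatter)), and hydrogen in place of methyl on the oxygen does the same (a 1.8-fold lower number from compound 1 to compound 3 (0.25 log units; within the scatter)). Hydroxy is the first group here at this aromatic carbon to bring a hydrogen-bond donor, yet bromo, methoxy and hydroxy all read alike at this position across compounds 1, 2 and 3. Nothing at hand accounts for these numbers or tests why the position reads this way.

As far as these compounds go, it remains open whether an amine or a carboxylic acid on this aromatic carbon would also stay within the scatter of these three compounds. Also open, from the compounds shown here alone, is what a longer chain would do with the 4-hydroxyphenyl group of compound 3 held fixed.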